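Triazole-linked diaryl ureas: aryl swap on the triazole nitrogen

The source may report more compounds than this note shows. Statements on the series, on what has been measured and on what is new or still open speak of the compounds shown alone.

Measured so far:
compound 1, `N#Cc1cccc(-n2cc(COc3cccc(NC(=O)Nc4ccc(Cl)c(C(F)(F)F)c4)c3)nn2)c1`, gives 2760 nM
compound 2, `CCc1ccccc1-n1cc(COc2cccc(NC(=O)Nc3ccc(Cl)c(C(F)(F)F)c3)c2)nn1`, gives 3530 nM
compound 3, `CCc1cccc(-n2cc(COc3cccc(NC(=O)Nc4ccc(Cl)c(C(F)(F)F)c4)c3)nn2)c1`, gives 37900 nM

All three were read in a functional assay on HepG2 cells (Homo sapiens) for inhibition, read by MTT assay, with a stated time of 72 h; on this read-out lower numbers stand for stronger inhibition and higher numbers for weaker inhibition. Compound 3 stands highest of the three numbers: the step of an 11-fold higher number from compound 2 to compound 3 (1.03 log units; beyond the scatter) and the step of a 14-fold higher number from compound 1 to compound 3 (1.14 log units; beyond the scatter) both lie beyond the scatter, so compound 3 is the weakest of the measured set. The step of a 1.3-fold higher number from compound 1 to compound 2 (0.11 log units; within the scatter) is within the scatter, so compounds 1 and 2 cannot be ordered against each other.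

Compound 4, `O=C(Nc1cccc(OCc2cn(-c3ccccc3Cl)nn2)c1)Nc1ccc(Cl)c(C(F)(F)F)c1`, is not yet measured. It differs from compound 3 by 2-chlorophenyl in place of 3-ethylphenyl on an aromatic nitrogen. Among the measured compounds shown here, the step that bears most directly is an 11-fold higher number from compound 2 to compound 3 (1.03 log units; beyond the scatter), where the same ethyl group moved on the phenyl ring and the number rose greatly; compound 4 reverses that placement while exchanging ethyl for chlorine, an exchange for which no measured step exists. The step of a 14-fold higher number from compound 1 to compound 3 (1.14 log units; beyond the scatter) also shows that the group on this phenyl ring moves the number by a large amount. On this basis the expected step is a large fall, a 13-fold lower number from compound 3 to compound 4 (1.10 log units; beyond the scatter), back toward the region of compounds 1 and 2. The estimate for compound 4 is 3000 nM, with an expected range from 1000 nM to 10000 nM.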

Compound 4, half-maximal inhibitory concentration: 1960 nM
The estimate for compound 4 lay 1.5-fold (0.18 log units) above the measured number; the measured number falls inside the stated range.
By their numbers in this assay, from the lowest: compounds 4, 1 and 2 (each within the scatter of the next); then compound 3.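

In this assay, 2-chlorophenyl in place of 3-ethylphenyl on the aromatic nitrogen gives a 19-fold lower number from compound 3 to compound 4 (1.29 log units; beyond the scatter), so a second group on this ring also separates from compound 3 by a large margin. Among the compounds shown here, the first measured exchange of ethyl for chloro at a single ring carbon gives a 1.8-fold lower number from compound 2 to compound 4 (0.26 log units; within the scatter), which is within the scatter, and the comparison with the nitrile gives a 1.4-fold lower number from compound 1 to compound 4 (0.15 log units; within the scatter), also within the scatter; compounds 1, 2 and 4 therefore form one group that cannot be ordered, with 2-ethylphenyl and 2-chlorophenyl not distinguished here, and compound 1 shows that the high number of compound 3 does not extend to every aryl group with its substituent placed as in 3-ethylphenyl. No measurement is available that explains why compound 3 stands apart from the other three.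

Open, going by these compounds, is whether chlorine placed as the ethyl is in compound 3 would stay with compounds 1, 2 and 4 or follow compound 3. Also open, on these data alone, is how this ring responds to an amine, a carboxylic acid or a chain longer than ethyl, and how an unsubstituted phenyl compares.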